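The source may report more compounds than this note shows. Statements on the series, on what has been measured and on what is new or still open speak of the compounds shown alone.

Working notes on the series, measured in a physicochemical assay for solubility; on this read-out lower numbers stand for lower solubility and higher numbers for higher solubility:

- Compound 1 `O=C(O)c1ccc(C(=O)/C(=C\c2cc([N+](=O)[O-])ccc2F)SCc2ccc(Br)cc2)cc1`: < 1000 ug/mL (a limit)
- Compound 2 `O=C(O)c1ccc(C(=O)/C(=C\c2ccc(F)c([N+](=O)[O-])c2)Sc2ccc(Br)cc2)cc1`: < 1000 ug/mL (a limit)
- Compound 3 `O=C(O)c1ccc(C(=O)/C(=C\c2ccc(Cl)c([N+](=O)[O-])c2)SCc2ccc(F)cc2)cc1`: < 1000 ug/mL (a limit)

None of the three compounds has a number yet; the whole set sits at one limit: the limit of < 1000 ug/mL in this assay, at which 3 of the 3 values shown sit. Compound 3 is reported only as a limit, < 1000 ug/mL. Among the compounds with values here, it therefore cannot be ranked against compound 1 or compound 2, and no measured step is available to size a structural change.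

The next compound is compound 4 `O=C(O)c1ccc(C(=O)/C(=C\c2ccc(Cl)c([N+](=O)[O-])c2)SCc2ccccc2F)cc1`. It carries 2-fluorophenyl in place of 4-fluorophenyl on a saturated chain carbon bound to a sulfur. The two compounds have the same atoms, joined differently.

Within the data shown here, with no measured step as a guide, the only anchor is the limit of compound 3, < 1000 ug/mL. No step beyond the usual scatter is expected in this assay, and no direction is favoured: a step that the limit leaves unreadable from compound 3 to compound 4. A further limit is the most likely report. Should a number appear, the estimate for compound 4 is 700 ug/mL, with an expected range from 200 ug/mL to 1000 ug/mL.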

Compound 4, solubility: < 1000 ug/mL
Compound 4: a limit, no number; the forecaster's own chance of this, stated with the estimate: 90%; the middle value is on the limit's open side.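

Compound 4 is reported only as a limit, < 1000 ug/mL. Within the data shown here, with compound 3 also a limit, no step from compound 3 to compound 4 can be read in this assay. The whole set now sits at one limit: the limit of < 1000 ug/mL in this assay, at which 4 of the 4 values shown sit.

The compounds shown leave open what number any of them would give and whether moving the fluorine changes it.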